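Phenyl in Place of Hydrogen on a Quiet Core

The source may hold more compounds than are shown below. What is called first, only, known or untested is meant among the compounds shown, and "the series" means these compounds.

Three compounds have so far been measured in an assay on isolated protein for inhibition of serine/threonine-protein kinase Chk2 (Homo sapiens), read by mobility shift assay, tested at 30 uM; on this read-out lower numbers stand for less inhibition and higher numbers for more inhibition at the one concentration tested (going by the name of the read-out):
Compound 1 `Cc1cc2nn(-c3ccccc3)c(N)c2c(=O)[nH]1` gives -4%.
Compound 2 `Nc1c2c(=O)[nH]c(-c3ccccc3)cc2nn1-c1ccccc1` gives -8%.
Compound 3 `COc1ccc(-c2cc3nn(-c4ccccc4)c(N)c3c(=O)[nH]2)cc1` gives -3%.

All three numbers sit close to zero, so none of these compounds shows clear inhibition. Compound 1 stands second highest of the three: its nearest neighbour is compound 3, a number 1 percentage points higher from compound 1 to compound 3 (within the scatter), and its furthest is compound 2, a number 4 percentage points lower from compound 1 to compound 2 (within the scatter). Compound 4 `Cc1[nH]c(=O)c2c(N)n(-c3ccccc3)nc2c1-c1ccccc1` is the next one to be tested. It differs from compound 1 in one place: phenyl in place of hydrogen on an aromatic carbon. The two steps just described bear on this change, since each likewise brings a phenyl group onto the shared core, and both stayed within the scatter. On that basis no step beyond the scatter is expected, a number 1 percentage points higher from compound 1 to compound 4 (within the scatter). Compound 4 is therefore estimated to give -3%, within a range from -15% to 10%.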

Compound 4, a percentage reported as inhibition, at one concentration (the size of the read-out at that concentration, not a potency): -1%
Compound 4: the middle estimate sits 2 percentage points below what was measured; the range from low to high includes it.
By their numbers in this assay, from the lowest: compounds 2, 1, 3 and 4 (each within the scatter of the next).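

Placing a phenyl on this aromatic carbon, ortho to a methyl group, gives a number 3 percentage points higher from compound 1 to compound 4 (within the scatter) in this assay. The core has now taken a phenyl at a second carbon, and this step, like the earlier swap of methyl for phenyl, stays within the scatter. Nothing available explains why the number barely moves here.

As far as these compounds go, whether an amine or a carboxylic acid at this carbon would give a step beyond the scatter remains open. So does whether a methoxy group on the new phenyl would change anything.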